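A few compounds are considered here, and "the series" means these few. Any claim that something is new, unique, unknown or untested is made for them only; others in the source may bear on it.

Measured in an ADME assay on L6 cells (Rattus norvegicus) for inhibition, read by resazurin assay, with a stated time of 72 h; a lower number here means a stronger inhibitor, a higher number a weaker inhibitor:
- Compound 1 `C[S+]([O-])C[C@H]1O[C@@H](n2cnc3c(N)nc(F)nc32)[C@H](O)[C@@H]1O`: 13000 nM
- Compound 2 `C[S+]([O-])C[C@H]1O[C@@H](n2cnc3c(N)nc(Cl)nc32)[C@H](O)[C@@H]1O`: 259000 nM
- Compound 3 `CC(=O)O[C@@H]1[C@H](OC(C)=O)[C@@H](CN=[N+]=[N-])O[C@H]1n1cnc2c(N)nc(Cl)nc21`: 141000 nM

Compound 2, at 259000 nM, stands with compound 3, at 141000 nM, at the high end of these numbers, the two within the scatter of each other. Compound 4 `CC(=O)NC[C@H]1O[C@@H](n2cnc3c(N)nc(Cl)nc32)[C@H](O)[C@@H]1O` keeps the core of compound 2 and carries acetamido on a saturated chain carbon bound to a saturated ring carbon: a group of 4 heavy atoms (2 carbon, 1 nitrogen, 1 oxygen; no ring) in place of a group of 3 heavy atoms (1 carbon, 1 oxygen, 1 sulfur; no ring), on a saturated chain carbon bound to a saturated ring carbon. Among the compounds with values here, the one measured step, a 20-fold higher number from compound 1 to compound 2 (1.30 log units; beyond the scatter), is large but concerns chloro in place of fluoro on an aromatic carbon, so it does not bear on this change. Within the data shown here, no measured step covers this exchange, so no step beyond the scatter is expected in this assay. The estimated step is a 1.3-fold lower number from compound 2 to compound 4 (0.11 log units; within the scatter). For compound 4 the estimated value is 200000 nM, with an expected range of 60000 nM to 400000 nM.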

Compound 4, half-maximal inhibitory concentration: 189000 nM
Compound 4: the middle estimate sits 1.1-fold (0.02 log units) above what was measured; the range from low to high includes it.
By their numbers in this assay, from the lowest: compound 1; then compounds 3, 4 and 2 (each within the scatter of the next).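

In this assay the exchange of acetamido for the group of 3 heavy atoms, on a saturated chain carbon bound to a saturated ring carbon, gives a 1.4-fold lower number from compound 2 to compound 4 (0.14 log units; within the scatter) and is the first change shown at this position. This position therefore takes acetamido, with its hydrogen-bond donor, without a change that can be read in this assay. No measured finding on hand accounts for this result. On these data alone, whether an amine or a longer acyl chain at this place would behave alike remains open, as does whether acetamido would give the same result alongside fluoro in place of chloro on the core.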